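A few compounds are considered here, and "the series" means these few. Any claim that something is new, unique, unknown or untested is made for them only; others in the source may bear on it.

Measured so far in an ADME assay on microsomes from liver (Homo sapiens) for metabolic stability, read by LC-MS, with a stated time of 10 min; a higher number here means that more of the compound is left, a lower number that less of the compound is left:
- compound 1 `CC(C)N1CCN(c2cccc3c2C[C@H](CN(C)[C@H]2CCCc4cccnc42)NC3)CC1` gives 56.6%
- compound 2 `CN(C[C@H]1Cc2c(cccc2N2CCN3CCC[C@@H]3C2)CN1)[C@H]1CCCc2cccnc21` gives 52.2%
- compound 3 `CN1CCN(c2cccc3c2C[C@H](CN(C)[C@H]2CCCc4cccnc42)NC3)CC1` gives 75.8%

Compound 3 stands highest of the three, and its steps to both others lie beyond the scatter. Compound 4 `C[C@@H]1CN(c2cccc3c2C[C@H](CN(C)[C@H]2CCCc4cccnc42)NC3)C[C@H](C)N1C` keeps the shared core and changes one group (3,4,5-trimethylpiperazin-1-yl in place of 4-methylpiperazin-1-yl on an aromatic carbon), with 3,4,5-trimethylpiperazin-1-yl in place of 4-methylpiperazin-1-yl on an aromatic carbon. Among the measured compounds shown here, two measured steps bear on this change. Methyl in place of isopropyl on an amine nitrogen in a ring gives a number 19.2 percentage points higher from compound 1 to compound 3 (beyond the scatter), and the replacement of the two-ring group gives a number 23.6 percentage points higher from compound 2 to compound 3 (beyond the scatter). Both steps end at the smaller group of compound 3, whereas compound 4 goes from that group to a larger one. For the measured compounds named here, a fall of similar size is therefore expected in this assay, although no measured compound carries this exact group. The expected change is a number 15.8 percentage points lower from compound 3 to compound 4 (beyond the scatter). For compound 4 the estimate is 60%, with an expected range of 43% to 77%.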

Compound 4, percent of the compound remaining: 24.6%
Estimate against measurement, compound 4: 35.4 percentage points above; the measured number lies below the stated range.
By their numbers in this assay, from the lowest: compound 4; then compounds 2 and 1 (each within the scatter of the next); then compound 3.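

In this assay, 3,4,5-trimethylpiperazin-1-yl in place of 4-methylpiperazin-1-yl on the aromatic carbon gives a number 51.2 percentage points lower from compound 3 to compound 4 (beyond the scatter), which shows that methyl groups added to the carbons of the piperazine ring can lower this read-out sharply even when the methyl on the nitrogen stays. The number is not set by the count of heavy atoms alone, since the groups of compound 1 and compound 2 have the same count as the new group, yet the steps are a number 32 percentage points lower from compound 1 to compound 4 (beyond the scatter) and a number 27.6 percentage points lower from compound 2 to compound 4 (beyond the scatter). Nothing available explains this fall.

Going by these compounds, it remains open whether a single added methyl, as in 3-methylpiperazin-1-yl, would account for part of the fall, and what role the two defined stereocentres play. On these data alone, it is also open how a morpholin-4-yl group, with oxygen in the ring, would read at this aromatic carbon.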